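Compound 3 to compound 4: substituting the ring nitrogen

A few compounds are considered here, and "the series" means these few. Any claim that something is new, unique, unknown or untested is made for them only; others in the source may bear on it.

- compound 1 `Cc1cc(C)cc(S(=O)(=O)c2c(C(=O)NC3CNC3)[nH]c3ccc(Cl)cc23)c1` gives 37300 nM
- compound 2 `Cc1cc(C)cc(S(=O)(=O)c2c(C(=O)N[C@@H]3CCNC3)[nH]c3ccc(Cl)cc23)c1` gives 37300 nM
- compound 3 `Cc1cc(C)cc(S(=O)(=O)c2c(C(=O)N[C@H]3CCNC3)[nH]c3ccc(Cl)cc23)c1` gives 10000 nM

In an ADME assay on MT4 cells (Homo sapiens) for cytotoxicity, read by MTT assay, with a stated time of 5 days (on this read-out lower numbers stand for higher toxicity in this test and higher numbers for lower toxicity in this test), compound 3 stands lowest of the three at 10000 nM. Compound 4 `Cc1cc(C)cc(S(=O)(=O)c2c(C(=O)N[C@H]3CCN(Cc4ccccc4C#N)C3)[nH]c3ccc(Cl)cc23)c1` differs from it by 2-cyanobenzyl in place of hydrogen on an amine nitrogen in a ring, with 2-cyanobenzyl in place of hydrogen on an amine nitrogen in a ring.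

Within the data shown here, three measured steps give the scale of the series so far: no change at the digits printed from compound 1 to compound 2 (within the scatter), a 3.7-fold lower number from compound 1 to compound 3 (0.57 log units; beyond the scatter) and a 3.7-fold lower number from compound 2 to compound 3 (0.57 log units; beyond the scatter). The last of these goes with the fact that compounds 2 and 3 differ only in the configuration as drawn. None of them places a group on the ring nitrogen, so they bear on the new change only indirectly. They concern ring size and configuration, and their size is no more than modest. A modest move towards a lower number in this assay is therefore expected, with wide uncertainty, taking compound 3 at 10000 nM as the starting point. The expected change is a 2.2-fold lower number from compound 3 to compound 4 (0.35 log units; beyond the scatter). For compound 4 the estimated value is 4500 nM, with an expected range of 1200 nM to 20000 nM.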

Compound 4, half-maximal cytotoxic concentration: > 228000 nM
Compound 4: no number, only a limit (the forecaster's own chance of this, stated with the estimate: 20%); at least 50-fold (1.70 log units) between middle value and limit.
By their numbers in this assay, from the lowest: compound 3; then compounds 1 and 2 (each within the scatter of the next). At a limit, above all of these: compound 4.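

In this assay, among these compounds, 2-cyanobenzyl in place of hydrogen on the amine nitrogen in the ring gives an at least 22-fold higher number from compound 3 to compound 4 (1.35 log units; beyond the scatter), a larger step than any among the earlier compounds, and it moves towards lower toxicity in this test. Compound 4 gives > 228000 nM, which is a limit of the assay and not a number. Substitution at this ring nitrogen therefore moves the read-out further than the changes of ring size and configuration seen so far, and the position accepts this group with no rise in toxicity in this test.

Going by these compounds, how far the read-out moves remains open at its upper end: the limit of > 228000 nM in this assay, at which 1 of the 4 values shown sits. A methyl or an unsubstituted benzyl on the same nitrogen would show whether the nitrile is needed for the step or whether any such substituent gives it.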